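A few compounds are considered here, and "the series" means these few. Any claim that something is new, unique, unknown or untested is made for them only; others in the source may bear on it.

Working notes on the series.

Two compounds have been run in a functional assay on HT-29 cells (Homo sapiens) for inhibition, read by sulforhodamine B assay, with a stated time of 48 h; a higher number here means a weaker inhibitor of growth, a lower number a stronger inhibitor of growth. Compound 1 `O=C(Nc1cccc(-n2cc(-c3ccncc3)c(-c3ccc(Cl)c(O)c3)n2)c1)Nc1ccc(Cl)c(Cl)c1` gives 4890 nM. Compound 2 `COc1cc(-c2nn(-c3cccc(NC(=O)c4cccc(C(F)(F)F)c4)c3)cc2-c2ccncc2)ccc1Cl` gives 1390 nM, which is the lowest of the two numbers; the gap to compound 1 is beyond the scatter, so compound 2 is the stronger growth inhibitor of the measured pair.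

Compound 3 `COc1cc(-c2nn(-c3cccc(NC(=O)c4ccccc4)c3)cc2-c2ccncc2)ccc1Cl` is not yet measured. It differs from compound 2 in one place: hydrogen in place of trifluoromethyl on an aromatic carbon, on an aromatic carbon of a six-membered aromatic ring of carbon only, meta to a large group. Among the measured compounds shown here, no single-change step between measured compounds exists here, so the size of this change is untested. For the measured compounds named here, with only two measured compounds, the expectation rests on the change itself, and the step from compound 2 to compound 3 is expected to be modest and toward weaker growth inhibition, a 2.5-fold higher number from compound 2 to compound 3 (0.40 log units; beyond the scatter). Compound 3 is therefore estimated at 3500 nM, with a range of 1200 nM to 10000 nM.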

Compound 3, concentration for 50% growth inhibition: 392 nM
For compound 3 the middle estimate is 8.9-fold (0.95 log units) above the measured one, and the stated range ends above it.
By their numbers in this assay, from the lowest: compound 3; then compound 2; then compound 1.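

In this assay the change from 3-(trifluoromethyl)phenyl to phenyl gives a 3.5-fold lower number from compound 2 to compound 3 (0.55 log units; beyond the scatter) and so moves toward stronger growth inhibition. Among the compounds shown here, this is the first single-change reading at this place, on an aromatic carbon of a six-membered aromatic ring of carbon only. It shows that trifluoromethyl is not required there for growth inhibition, since hydrogen does better in this pair, and nothing measured here explains the step.

The compounds shown leave open where other groups at this place, such as a methyl, an amine or a carboxylic acid, would fall relative to hydrogen and trifluoromethyl. They also leave open whether the same change would have a similar effect on the core of compound 1, which differs from compound 2 in more than one place.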